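This account rests on a few compounds, and the source may have more. Where it says the series, first, only, none or still open, it means among the compounds named here.

Compound 3 `C[Si](C)(C)CCOCn1c(CC(O)CO)cc(=O)[nH]c1=O` is one of three measured members of this set. In a functional assay on HeLa cells (Homo sapiens) for antiproliferative activity, read by MTT assay, with a stated time of 72 h (on this read-out lower numbers stand for stronger inhibition and higher numbers for weaker inhibition), compound 3 gives > 100000 nM, which is a limit of the assay rather than a number. Compound 1 `C[Si](C)(C)CCOCn1c(CC(O)(CO)CO)cc(=O)[nH]c1=O` likewise gives > 100000 nM in this assay, again a limit. Compound 2 `Cc1c(CC(O)COCc2ccccc2)n(COCC[Si](C)(C)C)c(=O)[nH]c1=O`, which also bears a methyl on an aromatic carbon of its core, gives > 100000 nM in this assay, once more a limit. The step that the two limits leave unreadable from compound 1 to compound 3 therefore cannot be sized. Compound 4 `Cc1c(CC(O)CO)n(COCC[Si](C)(C)C)c(=O)[nH]c1=O` has not yet been measured; it differs from compound 3 by methyl in place of hydrogen on an aromatic carbon. Going by the values given here, no measured step bears on this change, and the only evidence is the limit of > 100000 nM in this assay, at which 3 of the 3 values shown sit, so no shift beyond the scatter can be expected in this assay. Compound 4 is accordingly expected to give 200000 nM in this assay, within 60000 nM to 1000000 nM, and most probably reported as a limit. The expected step that the limit leaves unreadable from compound 3 to compound 4 is thus essentially none.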

Compound 4, half-maximal inhibitory concentration: > 100000 nM
Compound 4: a limit, no number; the forecaster's own chance of this, stated with the estimate: 85%; the middle value lies beyond the limit too.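

The steps from compound 3 to compound 4 and from compound 2 to compound 4 cannot be read, as all of these values are limits in this assay. The compounds shown leave open what size of effect, if any, the methyl or the benzyl has.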